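Alkene geometry switch in the cyclopropylamide series

The source may report more compounds than this note shows. Statements on the series, on what has been measured and on what is new or still open speak of the compounds shown alone.

Compound 3 `C/C(C(=O)NC1CC1)=C(\C)c1ccccc1` has been measured in a toxicity assay on the whole organism (strain Icem-CET (SPF Caw)) for cytotoxicity, with Mus musculus as the target (a lower number here means that less compound is needed, a higher number that more compound is needed for the effect), where compound 3 gives 300 mg/kg. Going by the values given here, compound 1 `COc1ccc(/C(C)=C(/C)C(=O)NC2CC2)cc1` gives 300 mg/kg in this assay, and the single change no change at the digits printed from compound 1 to compound 3 (within the scatter) leaves the number where it was. Compound 2 `C/C(C(=O)NC1CC1)=C(/C)c1ccc(F)cc1` gives 70 mg/kg, a lower number than compound 3 and beyond the scatter, so compound 3 and compound 1 together stand at the top of the three numbers.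

Compound 4 `C/C(C(=O)NC1CC1)=C(/C)c1ccccc1` keeps every atom and bond of compound 3 and differs only in how the alkene is drawn: the two compounds have the same atoms and bonds and differ only in configuration as drawn: 1 of 1 stereo elements differ; a double bond is drawn Z in compound 3 and E in compound 4. Among the compounds with values here, no measured step bears on this change; the one measured step swaps a ring substituent and is flat, and nothing tells how the double-bond geometry moves the number. In this assay compound 4 is therefore expected to give 300 mg/kg, with a wide range from 100 mg/kg to 900 mg/kg. For compound 4 the expected step is no change at the digits printed from compound 3 to compound 4 (within the scatter), no change beyond the scatter, held with low confidence.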

Compound 4, dose for half-maximal effect: 150 mg/kg
Compound 4: the middle estimate sits 2.0-fold (0.30 log units) above what was measured, and the stated range covers the measured number.
By their numbers in this assay, from the lowest: compound 2; then compounds 4, 1 and 3 (each within the scatter of the next).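

In this assay, the double-bond geometry now has a first reading, a 2.0-fold lower number from compound 3 to compound 4 (0.30 log units; within the scatter), so this switch does not separate from the scatter. Fluoro also gets its first single-change comparison: hydrogen in its place gives a 2.1-fold higher number from compound 2 to compound 4 (0.33 log units; beyond the scatter), a modest step and the only one listed so far that lies beyond the scatter. The geometry reading rests on a single structural fact: the fact that compounds 3 and 4 differ only in the configuration as drawn.

The compounds shown leave open whether the geometry switch behaves the same way with fluoro or methoxy on the aromatic carbon. They also leave open whether chloro or an amine on that carbon, or a longer chain in place of the cyclopropyl group, would shift the number in this series.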